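The source may hold more compounds than are shown below. What is called first, only, known or untested is meant among the compounds shown, and "the series" means these compounds.

Compound 1 `CC1(COc2ccc(OC(F)(F)F)cc2)Cn2cc([N+](=O)[O-])nc2O1`: in an ADME assay on MRC5 cells (Homo sapiens) for cytotoxicity, read by fluorescence, with a stated time of 72 h (on this read-out lower numbers stand for stronger inhibition and higher numbers for weaker inhibition), compound 1 gives > 64000 nM, which is a limit of the assay and not a number.
Compound 2 `CC1(COc2ccc(C(F)(F)F)cc2)Cn2cc([N+](=O)[O-])nc2O1`: in this assay compound 2 gives > 64000 nM, again a limit.
Compound 3 `CC1(COc2ccc(-c3ccc(C(F)(F)F)cc3)cn2)Cn2cc([N+](=O)[O-])nc2O1`: in this assay compound 3 gives > 64000 nM, also a limit.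

All three values sit at the limit of > 64000 nM in this assay, at which 3 of the 3 values shown sit. Between compound 2 and compound 1 the change is trifluoromethoxy in place of trifluoromethyl on an aromatic carbon; the step is a step that the two limits leave unreadable from compound 2 to compound 1. How the core of compound 2 differs from the core of compound 3 is not broken down here. Compound 4 `CC1(COc2ccc(-c3ccc(OC(F)(F)F)cc3)cn2)Cn2cc([N+](=O)[O-])nc2O1` is not yet measured; it differs from compound 3 by trifluoromethoxy in place of trifluoromethyl on an aromatic carbon, the same change as from compound 2 to compound 1. In this assay the expected step is a number no higher from compound 3 to compound 4 (the limit leaves the size open), resting on compound 1 and compound 2 both sitting at the limit of > 64000 nM in this assay, at which 3 of the 3 values shown sit. Compound 4 is expected to give about 64000 nM, most probably again only a limit, within an estimated range from 30000 nM to 150000 nM.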

Compound 4, half-maximal inhibitory concentration: > 64000 nM
Compound 4 was reported as a limit; the forecaster's own chance of this, stated with the estimate: 85%; the middle value sits exactly at the limit.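

Compound 3 and compound 4 both give only a limit in this assay, so no step can be read between them: the limit of > 64000 nM in this assay, at which 4 of the 4 values shown sit.

The compounds shown leave open whether trifluoromethoxy and trifluoromethyl differ at all in this read-out, and where any true value lies.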